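Acylsulfonamide in place of hydroxymethyl at the benzoxazole-ring position

This account rests on a few compounds, and the source may have more. Where it says the series, first, only, none or still open, it means among the compounds named here.

For the measured compounds named here, compound 2 `CCCCN(c1nc2c(CO)cccc2o1)[C@H](C)c1ccc(-c2ccccc2-c2nnn[nH]2)cc1` gives the lowest of the two numbers so far in a functional assay on CAL1 cells for inhibition of chemerin-like receptor 1 (Homo sapiens), with a stated time of 45 min (on this read-out lower numbers stand for stronger inhibition and higher numbers for weaker inhibition), at 24 nM. Going by the values given here, its only neighbour, compound 1 `CCCCN(c1nc2c(C(=O)NC)cccc2o1)[C@H](C)c1ccc(-c2ccccc2-c2nnn[nH]2)cc1`, reads 110 nM in this assay; the single measured step, hydroxymethyl in place of methylcarbamoyl, is a 4.6-fold lower number from compound 1 to compound 2 (0.66 log units; beyond the scatter).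

Compound 3 `CCCCN(c1nc2c(C(=O)NS(C)(=O)=O)cccc2o1)[C@H](C)c1ccc(-c2ccccc2-c2nnn[nH]2)cc1` carries the change ((methylsulfonyl)carbamoyl in place of hydroxymethyl on an aromatic carbon). Among the compounds with values here, no step between a carbamoyl and an acylsulfonamide has been measured here, so the only bearing comes from the step from compound 1 to compound 2: a carbonyl-bearing substituent at this aromatic carbon gave the higher number, and the hydroxymethyl the lower one. Within the data shown here, the entering (methylsulfonyl)carbamoyl again carries a carbonyl and is the largest group tried at this place, so a step back upward is expected, plausibly at least as far as the one seen for compound 1, with wide uncertainty because only one comparison exists. The expected step is a 6.3-fold higher number from compound 2 to compound 3 (0.80 log units; beyond the scatter). For compound 3 the estimate in this assay is 150 nM, with a range from 40 nM to 600 nM.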

Compound 3, half-maximal inhibitory concentration: 14 nM
Compound 3: middle estimate off by 11-fold (1.03 log units), on the high side; measured number outside the range, below it.
By their numbers in this assay, from the lowest: compounds 3 and 2 (each within the scatter of the next); then compound 1.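

At this aromatic carbon, a carbonyl-bearing group does not by itself go with the higher number in this assay: the (methylsulfonyl)carbamoyl of compound 3 and the hydroxymethyl of compound 2 cannot be told apart (a 1.7-fold lower number from compound 2 to compound 3 (0.23 log units; within the scatter)), although the entering group is much the larger of the two. What separates the two carbonyl-bearing groups is the substituent on the amide-type nitrogen, where methylsulfonyl in place of methyl gives a step beyond the scatter (a 7.9-fold lower number from compound 1 to compound 3 (0.90 log units; beyond the scatter)), so this nitrogen substituent, and not the carbonyl alone, tracks with the read-out across these three compounds. Nothing measured here gives a reason for either step.

Open, from the compounds shown here alone, is whether a carboxylic acid or a primary carboxamide at this aromatic carbon would read with compound 1 or with compound 2 and compound 3. Also open, going by these compounds, is how far the amide-type nitrogen tolerates change, for instance ethylsulfonyl, phenylsulfonyl or a longer alkylsulfonyl chain in place of methylsulfonyl.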